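A few compounds are considered here, and "the series" means these few. Any claim that something is new, unique, unknown or untested is made for them only; others in the source may bear on it.

Measured in a functional assay on SK-HEP1 cells (Homo sapiens) for inhibition, read by MTT assay, with a stated time of 72 h; a higher number here means a weaker inhibitor, a lower number a stronger inhibitor:
- Compound 1 `Nc1nc2cc(-c3nn(CCCCC(=O)NO)c4ncnc(N)c34)ccc2o1`: 6400 nM
- Compound 2 `CNC(=O)CCCCCCCn1nc(-c2ccc3oc(N)nc3c2)c2c(N)ncnc21`: 10700 nM

Compound 2 stands within the scatter of compound 1, so neither can be ranked above the other. Compound 3 `Nc1nc2cc(-c3nn(CCCCCCC(=O)NO)c4ncnc(N)c34)ccc2o1` has not yet been measured. Its change from compound 2 is hydroxycarbamoyl in place of (methylcarbamoyl)methyl on a saturated chain carbon, six bonds along the chain from an aromatic nitrogen. For the measured compounds named here, the one measured step that bears on this links the same two kinds of chain end, and it stays within the scatter (a 1.7-fold higher number from compound 1 to compound 2 (0.22 log units; within the scatter)). No step beyond the scatter is therefore expected in this assay (a 1.9-fold lower number from compound 2 to compound 3 (0.29 log units; within the scatter)). Compound 3 is estimated at 5500 nM (range 1200 nM to 12000 nM).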

Compound 3, half-maximal inhibitory concentration: 2690 nM
Estimate against measurement, compound 3: 2.0-fold (0.31 log units) above; the range from low to high includes it.
By their numbers in this assay, from the lowest: compound 3; then compounds 1 and 2 (each within the scatter of the next).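

In this assay, the hydroxycarbamoyl end now stands apart from the methylcarbamoyl end, with a 4.0-fold lower number from compound 2 to compound 3 (0.60 log units; beyond the scatter), a separation the earlier pair did not show. Chain length also matters with the hydroxycarbamoyl end kept, as 2-(hydroxycarbamoyl)ethyl in place of hydroxycarbamoyl gives a 2.4-fold lower number from compound 1 to compound 3 (0.38 log units; beyond the scatter). Nothing measured here explains either step.

Still open, from the compounds shown here alone, is whether an even longer chain carrying hydroxycarbamoyl would lower the number further, and whether a carboxylic acid or an amine at the chain end would match hydroxycarbamoyl.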